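This account rests on a few compounds, and the source may have more. Where it says the series, first, only, none or still open, it means among the compounds named here.

- compound 1 `CCCNC(=O)c1cc(Oc2ccc(NC(=O)c3nn(-c4ccc(C)cc4)c(=O)cc3C)cc2F)ccn1` with 18000 nM in the test below
- compound 2 `CCNC(=O)c1cc(Oc2ccc(NC(=O)c3nn(-c4ccc(C)cc4)c(=O)cc3C)cc2)ccn1` with 11600 nM in the same test

In a functional assay on A549 cells (Homo sapiens) for antiproliferative activity, read by MTT assay, with a stated time of 72 h (on this read-out higher numbers stand for weaker inhibition and lower numbers for stronger inhibition), compound 1 gives 18000 nM and compound 2 gives 11600 nM as its counterpart, so the two numbers lie within the usual scatter of each other and compound 1 does not stand apart from compound 2.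

Compound 3 `CCCNC(=O)c1cc(Oc2ccc(NC(=O)c3nn(-c4cccc(C(F)(F)F)c4)c(=O)cc3C)cc2F)ccn1` keeps the rest of compound 1 and changes in one place. It carries 3-(trifluoromethyl)phenyl in place of 4-methylphenyl on an aromatic nitrogen of the shared core.

Among the compounds with values here, both measured compounds carry 4-methylphenyl, so no measured pair shows what a change at this group does. Within the data shown here, the data therefore give no direction for the step, and only a change within the scatter is expected, with wide margins on either side. The estimate amounts to a 1.2-fold lower number from compound 1 to compound 3 (0.08 log units; within the scatter) and this expected step stays within the scatter. For compound 3 the value expected in this assay is 15000 nM with an estimated range from 5000 nM to 40000 nM.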

Compound 3, half-maximal inhibitory concentration: 9240 nM
For compound 3 the middle estimate is 1.6-fold (0.21 log units) above the measured one, and the stated range covers the measured number.
By their numbers in this assay, from the lowest: compounds 3, 2 and 1 (each within the scatter of the next).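

Within the data shown here, this is the first step that reads the aryl group on the aromatic nitrogen of the shared core: in this assay, putting 3-(trifluoromethyl)phenyl in place of 4-methylphenyl gives a 1.9-fold lower number from compound 1 to compound 3 (0.29 log units; within the scatter) and so the two compounds cannot be told apart on this read-out. The position therefore takes a group of 10 heavy atoms in place of one of 7, with trifluoromethyl at the 3-position of the phenyl ring instead of methyl at the 4-position, and the step still stays inside the scatter. No measurement at hand offers an explanation for this result.

Because the group and its place on the phenyl ring change in the same step, the compounds shown cannot separate the effect of one from the effect of the other. From the compounds shown here alone, it stays open whether plain phenyl, 4-(trifluoromethyl)phenyl or a phenyl ring carrying an amine or a carboxylic acid on this nitrogen would give a step beyond the scatter in either direction.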